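Swapping a ring substituent on a shared core

This account rests on a few compounds, and the source may have more. Where it says the series, first, only, none or still open, it means among the compounds named here.

Of the compounds shown here, two have been measured. Compound 1 `O=c1nc(N2CCN(CC3CCCCC3)CC2)sc2c([N+](=O)[O-])cc(C(F)(F)F)cc12` and compound 2 `Cc1ccc(C(=O)N2CCN(c3nc(=O)c4cc(C(F)(F)F)cc([N+](=O)[O-])c4s3)CC2)cc1` share the same core and differ only in the group carried on the amine nitrogen in a ring. In a physicochemical assay for solubility, read by HPLC (on this read-out higher numbers stand for higher solubility and lower numbers for lower solubility), compound 1 gives 9.07 ug/mL, and compound 2 gives 6.7 ug/mL. Of these two numbers compound 1 holds the higher one, but the step of a 1.4-fold lower number from compound 1 to compound 2 (0.13 log units; within the scatter) is too small to call a real difference. Compound 3 `O=C(C1CCCC1)N1CCN(c2nc(=O)c3cc(C(F)(F)F)cc([N+](=O)[O-])c3s2)CC1` is not yet measured; it differs from compound 1 by cyclopentylcarbonyl in place of cyclohexylmethyl on an amine nitrogen in a ring. Among the measured compounds shown here, the one measured step that bears on this change, the exchange of cyclohexylmethyl for (4-methylphenyl)carbonyl from compound 1 to compound 2, stayed within the scatter, and the change toward compound 3 is of the same kind, a carbonyl-bearing group replacing cyclohexylmethyl at the same place. The expected step is therefore a 1.1-fold lower number from compound 1 to compound 3 (0.05 log units; within the scatter), none beyond the scatter. Compound 3 is estimated at 8 ug/mL, with a range from 3 ug/mL to 20 ug/mL.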

Compound 3, solubility: 5.34 ug/mL
Beside the measured number, compound 3's estimate is 1.5-fold (0.18 log units) above it; the measured number falls inside the stated range.
By their numbers in this assay, from the lowest: compounds 3, 2 and 1 (each within the scatter of the next).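

At this amine nitrogen, a second carbonyl-bearing group, cyclopentylcarbonyl, also stays close to cyclohexylmethyl in this assay, with a 1.7-fold lower number from compound 1 to compound 3 (0.23 log units; within the scatter). The series now also allows a comparison between two carbonyl-bearing groups: cyclopentyl in place of 4-methylphenyl on the carbonyl carbon gives a 1.3-fold lower number from compound 2 to compound 3 (0.10 log units; within the scatter), so this read-out does not separate these two groups. No measurement here accounts for how close the three numbers lie.

The compounds shown leave open whether a very different group on this nitrogen, such as a carboxylic acid or an amine at the end of a longer chain, would produce a step beyond the scatter. They also leave open whether the same closeness would hold if the nitro group on the shared core were replaced by a nitrile.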